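The source may report more compounds than this note shows. Statements on the series, on what has been measured and on what is new or still open speak of the compounds shown alone.

Measured compounds in an ADME assay on MT4 cells (Homo sapiens) for cytotoxicity, read by MTT assay, with a stated time of 96 h; on this read-out higher numbers stand for lower toxicity in this test and lower numbers for higher toxicity in this test:
compound 1, `NS(=O)(=O)c1ccc(N2N=C(c3ccc(OCc4ccccc4)cc3)CC2c2ccc(F)cc2)cc1`, gives only a limit of > 100000 nM.
compound 2, `NS(=O)(=O)c1ccc(N2N=C(c3ccc(OCc4ccccc4)cc3)CC2c2ccc(Cl)cc2)cc1`, gives 70000 nM.
compound 3, `NS(=O)(=O)c1ccc(N2N=C(c3ccc(OCc4ccccc4)cc3)CC2c2cccc(Cl)c2)cc1`, gives 36000 nM.

Compound 2 and compound 3 share all their atoms, joined differently: 3-chlorophenyl in place of 4-chlorophenyl on a saturated ring carbon. The step between them, a 1.9-fold lower number from compound 2 to compound 3 (0.29 log units; within the scatter), is within the scatter, so the two values are read as alike. From compound 2 to compound 1 the change is fluoro in place of chloro on an aromatic carbon, and the step is an at least 1.4-fold higher number from compound 2 to compound 1 (0.15 log units; that floor lies within the scatter); its size is only a floor because compound 1 sits at the limit of > 100000 nM in this assay, at which 1 of the 3 values shown sits.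

Compound 4, `NS(=O)(=O)c1ccc(N2N=C(c3ccc(OCc4ccccc4)cc3)CC2c2cccc(F)c2)cc1`, has not been measured in this assay. It differs from compound 3 by fluoro in place of chloro on an aromatic carbon. Going by the values given here, this is the same kind of change as the one from compound 2 to compound 1, but not the same: there the fluoro sits para to a large group, here it sits meta to a large group. Compound 4 is expected to show a step of about a 1.5-fold higher number from compound 3 to compound 4 (0.18 log units; within the scatter), resting on an at least 1.4-fold higher number from compound 2 to compound 1 (0.15 log units; that floor lies within the scatter) seen for compound 1. The estimate for compound 4 is 55000 nM, expected between 25000 nM and 120000 nM.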

Compound 4, half-maximal cytotoxic concentration: 65000 nM
Compound 4: middle estimate off by 1.2-fold (0.07 log units), on the low side, within the range that was stated.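

In this assay, fluoro in place of chloro on an aromatic carbon can now be set side by side on two cores: the same change on two cores in this assay, an at least 1.4-fold higher number (0.15 log units; that floor lies within the scatter) from compound 2 to compound 1 and a 1.8-fold higher number (0.26 log units; within the scatter) from compound 3 to compound 4; the limit leaves it open whether they differ

The new step, a 1.8-fold higher number from compound 3 to compound 4 (0.26 log units; within the scatter), does not separate the two compounds it joins, and neither does a 1.1-fold lower number from compound 2 to compound 4 (0.03 log units; within the scatter), while an at least 1.5-fold lower number from compound 1 to compound 4 (0.18 log units; that floor lies within the scatter) offers only a floor. This shows that the change, carried to the core of compound 3, gives no step beyond the scatter, but it does not show that the change has the same size on both cores, since compound 1 gives only a limit and no number: the limit of > 100000 nM in this assay, at which 1 of the 4 values shown sits.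

The compounds shown leave open how this read-out responds when an amine, a methoxy group or a carboxylic acid stands in place of the halogen on this ring. They also leave open whether fluoro in place of chloro reads the same on any other aromatic carbon of the shared core.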